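Anilino series: chloro added on the anilino ring

This account rests on a few compounds, and the source may have more. Where it says the series, first, only, none or still open, it means among the compounds named here.

Measured so far:
compound 1, `N#Cc1c(Cl)nc(SCC(=O)Nn2c(COc3ccc(Cl)cc3Cl)nc3ccccc3c2=O)nc1-c1ccc(O)cc1`, 73.7%
compound 2, `N#Cc1c(Nc2ccc(Cl)cc2)nc(SCC(=O)Nn2c(COc3ccc(Cl)cc3Cl)nc3ccccc3c2=O)nc1-c1ccc(Cl)cc1`, 61.4%
compound 3, `N#Cc1c(Nc2ccccc2)nc(SCC(=O)Nn2c(COc3ccc(Cl)cc3Cl)nc3ccccc3c2=O)nc1-c1ccc(O)cc1`, 91.2%

In a functional assay on the whole organism (strain albino) for inhibition, with Rattus norvegicus as the target, read by paw edema, with stated times of 1 h and 2 h, at a dose of 100 mg/kg by the oral route (on this read-out lower numbers stand for less inhibition and higher numbers for more inhibition at the one dose given (going by the name of the read-out)), compound 3 stands highest of the three numbers, with compound 1 nearest and compound 2 furthest. Compound 4, `N#Cc1c(Nc2ccc(Cl)cc2)nc(SCC(=O)Nn2c(COc3ccc(Cl)cc3Cl)nc3ccccc3c2=O)nc1-c1ccc(O)cc1`, differs from compound 3 by chloro in place of hydrogen on an aromatic carbon, placed on an aromatic carbon of a six-membered aromatic ring of carbon only. Among the compounds with values here, the only step known is a number 17.5 percentage points higher from compound 1 to compound 3 (beyond the scatter), which concerns a different change and does not bear on this one. Compound 2 carries the same (4-chlorophenyl)amino group but differs from compound 4 in a second place as well, so its value in this assay only loosely guides the outcome. A small downward step, a number 9.2 percentage points lower from compound 3 to compound 4 (within the scatter), is expected. Compound 4 is estimated at 82%, within 65% to 95%.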

Compound 4, a percentage reported as inhibition, in the whole organism at one dose (the size of the read-out at that dose, not a potency): 77.2%
Compound 4: the middle estimate sits 4.8 percentage points above what was measured, within the range that was stated.
By their numbers in this assay, from the lowest: compound 2; then compounds 1 and 4 (each within the scatter of the next); then compound 3.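

In this assay, within the data shown here, chloro in place of hydrogen on the anilino ring gives a number 14 percentage points lower from compound 3 to compound 4 (beyond the scatter), the first reading of this position, and the response survives the change in good part. With that ring kept, hydroxy in place of chloro on an aromatic carbon gives a number 15.8 percentage points higher from compound 2 to compound 4 (beyond the scatter), while (4-chlorophenyl)amino in place of chloro gives only a number 3.5 percentage points higher from compound 1 to compound 4 (within the scatter), against a number 17.5 percentage points higher from compound 1 to compound 3 (beyond the scatter) for the plain anilino group. Nothing available accounts for these steps.

Open, from the compounds shown here alone, is how fluoro, methoxy or an amine would read at this same place on the anilino ring. Also open, going by these compounds, is whether the chloro step would hold with a different group in place of the hydroxy.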